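This account rests on a few compounds, and the source may have more. Where it says the series, first, only, none or still open, it means among the compounds named here.

Measured compounds in a physicochemical assay for lipophilicity, read by LC-MS, in phosphate buffer, measured as octanol-water partition, with a stated time of 30 min, at pH 7.4, tested at 200 mM; on this read-out lower numbers stand for lower lipophilicity and higher numbers for higher lipophilicity:
compound 1, `Cc1ccc(Oc2ccc3nc(COc4cccc(C(=O)O)c4)n(C)c3n2)cc1F`, gives 2.1
compound 2, `Cc1cc(C)cc(Oc2ccc3nc(COc4cccc(C(=O)O)c4)n(C)c3n2)c1`, gives 2.3
compound 3, `Cn1c(COc2cccc(C(=O)O)c2)nc2ccc(Oc3ccccn3)cc21`, gives 0.4

Compound 3 stands lowest of the three, well apart from the other two: compound 1 gives 2.1 and compound 2 gives 2.3, both beyond the usual scatter of compound 3. The three share a core and differ only in the aromatic ring carried on the oxygen; compound 3 is the one bearing a pyridin-2-yl there.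

Compound 4, `Cn1c(COc2cccc(C(=O)O)c2)nc2ccc(Oc3ncc(Cl)cc3F)cc21`, has not yet been measured. It differs from compound 3 in one place: 5-chloro-3-fluoropyridin-2-yl in place of pyridin-2-yl on an oxygen on an aromatic ring.

Among the compounds with values here, only one measured step exists, a number 0.20 log units higher from compound 1 to compound 2 (within the scatter), which exchanges one substituted phenyl for another and therefore says little about adding a chlorine and a fluorine to a pyridin-2-yl. Within the data shown here, no measured pair shows that exact change, so the expectation rests mainly on the gap between compound 3 and compound 1. For compound 4 a step of a number 0.90 log units higher from compound 3 to compound 4 (beyond the scatter) is expected, upward from compound 3, clearly beyond the scatter. Compound 4 is estimated at 1.3, with a likely range from 0.8 to 1.8.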

Compound 4, distribution coefficient: 1.3
Beside the measured number, compound 4's estimate shows no gap at the digits printed, and the stated range covers the measured number.
By their numbers in this assay, from the lowest: compound 3; then compound 4; then compounds 1 and 2 (each within the scatter of the next).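

In this assay putting 5-chloro-3-fluoropyridin-2-yl in place of pyridin-2-yl on an oxygen on an aromatic ring gives a number 0.90 log units higher from compound 3 to compound 4 (beyond the scatter) and shows that adding these two halogen atoms to this ring can move the number. The one earlier step, between compound 1 and compound 2, exchanged one substituted phenyl for another and stayed within the scatter, so this is the only step shown that clearly shifts the read-out. No measurement shown here explains the size of this rise.

As far as these compounds go, the chlorine and the fluorine enter together, so the share of each in the step remains unknown. Also open, from the compounds shown here alone, is what an amine or a nitrile in place of the chlorine would do to this number.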